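Fluorine and Ring Configuration in a Weak Cytidine-Like Series

The source may hold more compounds than are shown below. What is called first, only, known or untested is meant among the compounds shown, and "the series" means these compounds.

Measured compounds:
Compound 1 `C[C@]1(CO)OC[C@@H](n2ccc(N)nc2=O)O1` gives 30000 nM in a functional assay on CCRF-CEM cells (Homo sapiens) for inhibition; on this read-out higher numbers stand for weaker inhibition and lower numbers for stronger inhibition.
Compound 2 `C[C@]1(CO)OC[C@@H](n2cc(F)c(N)nc2=O)O1` gives only a limit, > 100000 nM, in this assay.
Compound 3 `CC1(CO)OC[C@@H](n2ccc(N)nc2=O)O1` gives only a limit, > 100000 nM, in this assay.

Compound 2 differs from compound 1 by fluoro in place of hydrogen on an aromatic carbon; this change produced an at least 3.3-fold higher number from compound 1 to compound 2 (0.52 log units; beyond the scatter). The cores of compound 1 and compound 3 differ as follows: the two compounds have the same atoms and bonds; at least one stereo element is drawn with a configuration in one of them and without one in the other: 1 of 2 stereo elements differ; a stereocentre at a saturated ring carbon is drawn S in compound 1 and without a configuration in compound 3; this produced an at least 3.3-fold higher number from compound 1 to compound 3 (0.52 log units; beyond the scatter). Both steps are open-ended because of the limit of > 100000 nM in this assay, at which 2 of the 3 values shown sit.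

Compound 4 `CC1(CO)OC[C@@H](n2cc(F)c(N)nc2=O)O1` has not been measured. It differs from compound 3 by fluoro in place of hydrogen on an aromatic carbon, the same change made between compound 1 and compound 2, at a place described in identical words. Since compound 3 already sits at a limit, > 100000 nM, and the same change weakened compound 1 by an at least 3.3-fold higher number from compound 1 to compound 2 (0.52 log units; beyond the scatter), the step for compound 4 is expected to be a step that the limit leaves unreadable from compound 3 to compound 4. In this assay compound 4 is expected to give 300000 nM, most likely again only a limit.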

Compound 4, half-maximal inhibitory concentration: > 100000 nM
Compound 4: only a limit was reported; the forecaster's own chance of this, stated with the estimate: 90%; the middle value is on the limit's open side.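

Compound 4 gives only a limit, > 100000 nM, in this assay. Compound 2 and compound 3 also sit at limits, so neither step to compound 4 can be read. The compounds shown leave open how large the effect of fluoro is when the stereocentre is drawn without a configuration, and how large the effect of that stereocentre is when fluoro is present.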